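Methyl in Place of Nitro on the Shared Core

The source may report more compounds than this note shows. Statements on the series, on what has been measured and on what is new or still open speak of the compounds shown alone.

Compound 2 `O=C(CCCCCCC(=O)Nc1nc2ccc([N+](=O)[O-])cc2s1)NO` carries a nitro group on the aromatic ring of its core and ends in a hydroxamic acid. In a functional assay on PC-3 cells (Homo sapiens) for cytotoxicity (a higher number here means a weaker inhibitor, a lower number a stronger inhibitor), compound 2 gives 1.28 ug/mL, the lowest of the two numbers reported. Its closest neighbour is compound 1 `COc1ccc2nc(NC(=O)CCCCCCC(=O)NO)sc2c1`, which differs only by a methoxy group in place of the nitro and gives 1.56 ug/mL; that step, a 1.2-fold lower number from compound 1 to compound 2 (0.09 log units; within the scatter), lies within the scatter. Compound 3 `O=C(CCCCC(=O)Nc1nc2ccc([N+](=O)[O-])cc2s1)NO`, which has a shorter chain, is recorded only as a limit of > 30 ug/mL in this assay. The step of an at least 23-fold higher number from compound 2 to compound 3 (1.36 log units; beyond the scatter) shows that shortening the chain costs a great deal, but it says nothing about substituents on the ring.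

Compound 4 `Cc1ccc2nc(NC(=O)CCCCCCC(=O)NO)sc2c1` differs from compound 2 by methyl in place of nitro on an aromatic carbon. For the measured compounds named here, the only measured step that bears on a ring substituent is the methoxy-to-nitro change, which stayed within the scatter, so no step beyond the scatter is expected here. Compound 4 is therefore estimated at 1.5 ug/mL, within 0.7 ug/mL to 3.5 ug/mL. The expected change is a 1.2-fold higher number from compound 2 to compound 4 (0.07 log units; within the scatter).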

Compound 4, half-maximal inhibitory concentration: 0.53 ug/mL
Estimate against measurement, compound 4: 2.8-fold (0.45 log units) above; the whole stated range lies above it.
By their numbers in this assay, from the lowest: compound 4; then compounds 2 and 1 (each within the scatter of the next). At a limit, above all of these: compound 3.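

In this assay, the substituent on this aromatic carbon does matter: a 2.4-fold lower number from compound 2 to compound 4 (0.38 log units; beyond the scatter), and a 2.9-fold lower number from compound 1 to compound 4 (0.47 log units; beyond the scatter). Both steps are modest, but both lie beyond the scatter, so methyl stands apart from nitro and methoxy, two groups that had looked interchangeable at this carbon. Nothing available here bears on the reason for this difference.

Going by these compounds, what remains open is how other groups on this carbon, such as an amine, a chlorine atom or an ethyl group, would compare with methyl, and whether a bare ring hydrogen would do as well. On these data alone, it is also open whether methyl in place of nitro would give a similar step on the shorter chain of compound 3.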